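A Methoxy for a Chloro on a Well-Tolerated Scaffold

A few compounds are considered here, and "the series" means these few. Any claim that something is new, unique, unknown or untested is made for them only; others in the source may bear on it.

Compound 2 `O=c1oc2ccccc2cc1-c1cn2nc(-c3c([O-])[o+]nn3-c3ccc(Cl)cc3)sc2n1` carries a chloro on one of its outer rings. In a functional assay on HT-29 cells (Homo sapiens) for cytotoxicity, read by sulforhodamine B assay (a higher number here means that more compound is tolerated, a lower number that less compound is tolerated), compound 2 gives only a limit, > 80 ug/mL, and no number. Its close relative, compound 1 `O=c1oc2ccccc2cc1-c1cn2nc(-c3c([O-])[o+]nn3-c3ccccc3)sc2n1`, has hydrogen in place of that chloro. In this assay compound 1 likewise reaches only a limit, > 70 ug/mL. The step that the two limits leave unreadable from compound 1 to compound 2 cannot be read in size because the limit of > 70 ug/mL in this assay, at which 1 of the 2 values shown sits, and the limit of > 80 ug/mL in this assay, at which 1 of the 2 values shown sits, both hold only a limit rather than a number.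

Compound 3 `COc1ccc(-n2n[o+]c([O-])c2-c2nn3cc(-c4cc5ccccc5oc4=O)nc3s2)cc1` is the compound still to be measured. It differs from compound 2 in one place: methoxy in place of chloro on an aromatic carbon. Among the compounds with values here, only the step from compound 1 to compound 2 bears on this kind of change at that position, and since its size is unreadable, no direction can be drawn from it. Both measured compounds sit at the limit. Compound 3 is therefore expected to be tolerated in a similar way, with a step that the limit leaves unreadable from compound 2 to compound 3 that is expected to stay within the scatter. The estimate for compound 3 in this assay is 90 ug/mL, in a range from 40 ug/mL to 200 ug/mL.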

Compound 3, concentration lethal to 50% of the cells: > 70 ug/mL
Compound 3 was reported as a limit; the forecaster's own chance of this, stated with the estimate: 70%; the middle value lies beyond the limit too.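

In this assay, compound 3 gives only a limit, as do compound 1 and compound 2, so the steps from compound 1 and from compound 2 to compound 3 cannot be read in size. The compounds shown leave open where their true values lie, and whether hydrogen, chloro or methoxy at this position makes any difference.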